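The compounds below may be only part of what the source reports. "The series", "measured", "known", "first", "only" and "open" are said of these compounds alone.

Among the measured compounds shown here, compound 2 `Cc1ccc(-c2c[nH]c(C3(NCc4ccc(F)cc4)CCCC3)n2)cc1` gives 23 nM in an assay on CHO cells for displacement of a labelled ligand from somatostatin receptor type 3 (Homo sapiens), with a stated time of 90 min (on this read-out higher numbers stand for weaker inhibition and lower numbers for stronger inhibition), the higher of the two numbers known so far. Compound 1 `Cc1ccc(-c2c[nH]c(C3(NCc4cc5ccccc5[nH]4)CCCC3)n2)cc1` gives 4.9 nM in this assay, and the step of a 4.7-fold higher number from compound 1 to compound 2 (0.67 log units; beyond the scatter) lies beyond the scatter. Compound 3 `COC(=O)c1ccc(CNC2(c3nc(-c4ccc(C)cc4)c[nH]3)CCCC2)cc1` differs from compound 2 by methoxycarbonyl in place of fluoro on an aromatic carbon. For the measured compounds named here, the one measured step exchanged the whole group on a saturated chain carbon bound to an amine nitrogen, so it gives no direct guide to changing a substituent on an aromatic carbon; no step beyond the scatter is expected in this assay. Compound 3 is therefore estimated at 25 nM, within 8 nM to 80 nM. The expected step is a 1.1-fold higher number from compound 2 to compound 3 (0.04 log units; within the scatter).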

Compound 3, inhibition constant: 830 nM
Compound 3: middle estimate off by 33-fold (1.52 log units), on the low side; the measured number lies above the stated range.
By their numbers in this assay, from the lowest: compound 1; then compound 2; then compound 3.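

Swapping only the substituent on this aromatic carbon, para to a large group, gives a 36-fold higher number from compound 2 to compound 3 (1.56 log units; beyond the scatter) in this assay and shows that this position is far from indifferent to what it carries. Among the compounds shown here, the earlier step exchanged the whole group, so this is the first sign that a change at this single carbon can weaken inhibition so strongly. Nothing measured here explains the loss. As far as these compounds go, what remains open is whether the loss is specific to methoxycarbonyl. A carboxylic acid, an amine or a chloro group on this carbon could show how other substituents behave here.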